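Bromo to 4-chlorophenyl on the shared core

A few compounds are considered here, and "the series" means these few. Any claim that something is new, unique, unknown or untested is made for them only; others in the source may bear on it.

Compounds 1, 2 and 3 share one core and differ only at a single aromatic carbon. Compound 1 `Cc1[nH]n(-c2nc3cc(-c4ccccc4)ccc3[nH]2)c(=O)c1Cc1ccccc1` carries phenyl there, compound 2 `Cc1[nH]n(-c2nc3cc(C(C)(C)C)ccc3[nH]2)c(=O)c1Cc1ccccc1` tert-butyl and compound 3 `Cc1[nH]n(-c2nc3cc(Br)ccc3[nH]2)c(=O)c1Cc1ccccc1` bromo. In an assay on isolated protein for inhibition of alpha-ketoglutarate-dependent dioxygenase alkB homolog 3 (Homo sapiens), read by polymerase chain reaction, with a stated time of 1 h (a higher number here means a weaker inhibitor, a lower number a stronger inhibitor), compound 1 gives 810 nM, compound 2 gives 640 nM and compound 3 gives 490 nM. Going by the values given here, the steps are a 1.3-fold lower number from compound 1 to compound 2 (0.10 log units; within the scatter), a 1.7-fold lower number from compound 1 to compound 3 (0.22 log units; within the scatter) and a 1.3-fold lower number from compound 2 to compound 3 (0.12 log units; within the scatter), so the three numbers sit together within the scatter and no compound can be called the strongest. Compound 3 holds the lowest of the three numbers, with compound 2 nearest and compound 1 furthest.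

Compound 4 `Cc1[nH]n(-c2nc3cc(-c4ccc(Cl)cc4)ccc3[nH]2)c(=O)c1Cc1ccccc1` makes the change (4-chlorophenyl in place of bromo on an aromatic carbon). The step that bears on it most directly is the reverse of a 1.7-fold lower number from compound 1 to compound 3 (0.22 log units; within the scatter), where an aryl group stood in place of bromo, and that step lay within the scatter. A move back to an aryl group is therefore expected to give at most a small rise in the number, not beyond the scatter. For compound 4 in this assay the estimate is 700 nM, within 350 nM to 1400 nM, which means an expected step of a 1.4-fold higher number from compound 3 to compound 4 (0.15 log units; within the scatter).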

Compound 4, half-maximal inhibitory concentration: 1500 nM
For compound 4 the middle estimate is 2.1-fold (0.33 log units) below the measured one; measured number outside the range, above it.
By their numbers in this assay, from the lowest: compounds 3, 2, 1 and 4 (each within the scatter of the next, the first and the last beyond it).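

With a 3.1-fold higher number from compound 3 to compound 4 (0.49 log units; beyond the scatter) and a 2.3-fold higher number from compound 2 to compound 4 (0.37 log units; beyond the scatter) as modest steps beyond the scatter in this assay this aromatic carbon no longer looks indifferent to its substituent, as the first three compounds left it. The separation appears only when 4-chlorophenyl is set against bromo or tert-butyl, not against phenyl. Chloro in place of hydrogen on an aromatic carbon gives a 1.9-fold higher number from compound 1 to compound 4 (0.27 log units; within the scatter) and stays within the scatter, so compound 4 and compound 1 cannot be told apart here.

No measurement among these compounds offers an explanation for the rise in the number. Still open, on these data alone, is whether an amine, a carboxylic acid or a longer alkyl chain on this carbon would move the number further in either direction, and whether chloro elsewhere on the phenyl group would matter.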